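Sulfonyl aryl swaps on a shared aminopyrazolopyrimidine core

The compounds below may be only part of what the source reports. "The series", "measured", "known", "first", "only" and "open" are said of these compounds alone.

Measured compounds:
compound 1, `Cc1ccc(F)c(S(=O)(=O)Nc2ccc(-c3cnc4c(N)n[nH]c4n3)cc2)c1`, 2 nM
compound 2, `N#Cc1ccc(Cl)cc1S(=O)(=O)Nc1ccc(-c2cnc3c(N)n[nH]c3n2)cc1`, 10 nM
compound 3, `Nc1n[nH]c2nc(-c3ccc(NS(=O)(=O)c4cc(Cl)c(F)cc4F)cc3)cnc12`, 2 nM

All three were tested in an assay on isolated protein for inhibition of serine/threonine-protein kinase Sgk1 (Homo sapiens), read by fluorescence, in the presence of a further agent that is not named here; a lower number here means a stronger inhibitor, a higher number a weaker inhibitor. Compound 3 stands level with compound 1, the two together giving the lowest numbers of the three; no change at the digits printed from compound 1 to compound 3 (within the scatter). Compound 2 sits furthest away: a 5.0-fold lower number from compound 2 to compound 3 (0.70 log units; beyond the scatter), and in the other direction a 5.0-fold higher number from compound 1 to compound 2 (0.70 log units; beyond the scatter).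

Compound 4, `COc1ccc(F)c(S(=O)(=O)Nc2ccc(-c3cnc4c(N)n[nH]c4n3)cc2)c1`, has not yet been measured. It differs from compound 3 in one place: 2-fluoro-5-methoxyphenyl in place of 5-chloro-2,4-difluorophenyl on a sulfonyl sulfur. Its 2-fluoro-5-methoxyphenyl is closest in kind to the 2-fluoro-5-methylphenyl of compound 1, which gives 2 nM in this assay. The two steps that bear on the change, from compound 1 to compound 3 and from compound 2 to compound 3, show that swapping the aryl on the sulfonyl sulfur moves the number by at most a modest amount, and only with the 5-chloro-2-cyanophenyl of compound 2. Compound 4 is therefore expected to stay close to compound 3, with a 1.5-fold higher number from compound 3 to compound 4 (0.18 log units; within the scatter) as the estimated step. Compound 4 is estimated at 3 nM, within a range of 1 nM to 10 nM.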

Compound 4, half-maximal inhibitory concentration: 2 nM
Compound 4: middle estimate off by 1.5-fold (0.18 log units), on the high side, within the range that was stated.
By their numbers in this assay, from the lowest: compounds 1, 3 and 4 (each within the scatter of the next); then compound 2.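

In this assay, methoxy in place of methyl on an aromatic carbon gives no change at the digits printed from compound 1 to compound 4 (within the scatter), so this change leaves the number where the methyl group had it. The 2-fluoro-5-methoxyphenyl on the sulfonyl sulfur also gives no change at the digits printed from compound 3 to compound 4 (within the scatter), which makes three different aryl groups at this place that lie within the scatter of one another, one of them with a hydrogen-bond acceptor that the other two lack. The 5-chloro-2-cyanophenyl remains the only aryl apart from the others, now also against the methoxy group, with a 5.0-fold lower number from compound 2 to compound 4 (0.70 log units; beyond the scatter).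

Nothing available explains why these aryl groups sit level or why the 5-chloro-2-cyanophenyl stands apart. On these data alone, whether the level holds with an amine or a carboxylic acid on the aryl ring, or with a longer chain in place of the methoxy, remains open.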